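This account rests on a few compounds, and the source may have more. Where it says the series, first, only, none or still open, it means among the compounds named here.

Compound 1 `CCC[C@H](CO)Nc1nc(N)nc2cccnc12`: 19000 nM
Compound 2 `CCCC[C@@H](CO)Nc1nc(N)nc2cccnc12`: 420 nM
Compound 3 `CCCC[C@H](CO)Nc1nc(N)nc2cccnc12`: 790 nM

All three were tested in an assay on tissue (PBMC cells) for agonist activity at Toll-like receptor 8 (Homo sapiens), with a stated time of 24 h (on this read-out higher numbers stand for an effect only at larger amounts of compound and lower numbers for an effect already at smaller amounts), a measure of how much compound is needed to switch on the receptor. Among the three numbers compound 3 stands second highest, with compound 2 nearest and compound 1 furthest away. Two measured steps lead to compound 3. The first lengthens the side chain: a 24-fold lower number from compound 1 to compound 3 (1.38 log units; beyond the scatter), a large gain. The second only flips the drawn configuration: a 1.9-fold higher number from compound 2 to compound 3 (0.27 log units; within the scatter), a difference that stays within the scatter, which fits (the fact that compounds 2 and 3 differ only in the configuration as drawn).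

Compound 4 `CCCC[C@H](CCO)Nc1nc(N)nc2cccnc12` is the next step. It keeps the longer chain of compound 3 and alters the polar arm instead: hydroxymethyl in place of hydroxy on a saturated chain carbon, two bonds along the chain from a nitrogen on an aromatic ring. Going by the values given here, neither measured step bears directly on this change, since one concerns chain length on the other arm and the other concerns configuration alone, so there is no measured precedent for moving the hydroxyl one carbon further from the branching carbon. A modest step is expected, most likely toward a higher number, but one that could also fall within the scatter. For compound 4 the expected step is a 2.0-fold higher number from compound 3 to compound 4 (0.31 log units; beyond the scatter). Compound 4 is therefore estimated at 1600 nM, with a range from 400 nM to 6500 nM.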

Compound 4, half-maximal effective concentration: 4300 nM
The estimate for compound 4 lay 2.7-fold (0.43 log units) below the measured number; low and high end bracket the measured number.
By their numbers in this assay, from the lowest: compounds 2 and 3 (each within the scatter of the next); then compound 4; then compound 1.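

In this assay, the arm that carries the hydroxyl turns out to be sensitive to a single added carbon, with hydroxymethyl becoming 2-hydroxyethyl in a 5.4-fold higher number from compound 3 to compound 4 (0.74 log units; beyond the scatter), so more compound is needed for the same effect. Going by these compounds alone, the earlier steps covered only the length of the other arm and the configuration as drawn, so this is the first measured sign that this arm matters too: the count of hydrogen-bond donors and acceptors stays the same and neither group carries a net charge, yet the number moves beyond the scatter. The one fact at hand concerns configuration alone and does not bear on this change, so nothing shown here explains the shift.

As far as these compounds go, how an amine or a carboxylic acid in place of the hydroxyl would read remains open, and so does whether the hydroxyl is needed on this arm at all. A single step also cannot tell whether a longer arm such as 3-hydroxypropyl would push the number higher still, or how the opposite configuration of compound 4 would read.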